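Isopropoxy for (propylcarbonyl)oxy: expected effect on cytotoxicity

The source may report more compounds than this note shows. Statements on the series, on what has been measured and on what is new or still open speak of the compounds shown alone.

Compound 1 `CCCC(=O)Oc1ccc2oc(/C=C/[S+](C)[O-])cc(=O)c2c1`, compound 2 `COc1ccc2c(=O)cc(/C=C/[S+](C)[O-])oc2c1` and compound 3 `C[S+]([O-])/C=C/c1oc2ccccc2c(=O)c1Cc1ccccc1` have been measured in a functional assay on A549 cells (Homo sapiens) for cytotoxicity, with a stated time of 48 h; a higher number here means a weaker inhibitor, a lower number a stronger inhibitor. Compound 1 gives 2200 nM, level with compound 2 at 2200 nM, and together these are the highest of the three numbers. Compound 3 gives 1300 nM, a lower number that still lies within the scatter of compound 1, so no order among the three is established.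

Compound 4 `CC(C)Oc1ccc2oc(/C=C/[S+](C)[O-])cc(=O)c2c1` is not yet measured. It differs from compound 1 in one place: isopropyl in place of propylcarbonyl on an oxygen on an aromatic ring. For the measured compounds named here, no measured pair differing in a single place exists, so no measured step guides this change. Because compound 2, which also carries an oxygen on an aromatic ring of the core, gives 2200 nM level with compound 1, the step of no change at the digits printed from compound 1 to compound 4 (within the scatter) is expected to be none beyond the scatter. Compound 4 is therefore estimated at 2200 nM, within 1000 nM to 4800 nM.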

Compound 4, half-maximal inhibitory concentration: 1500 nM
The estimate for compound 4 lay 1.5-fold (0.17 log units) above the measured number; the measured number falls inside the stated range.
By their numbers in this assay, from the lowest: compounds 3, 4, 1 and 2 (each within the scatter of the next).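

For the compounds shown here, the first single-place pair shows that, in this assay, isopropyl in place of propylcarbonyl on an oxygen on an aromatic ring gives a 1.5-fold lower number from compound 1 to compound 4 (0.17 log units; within the scatter), a step within the scatter. The carbonyl can therefore leave this oxygen without a change beyond the scatter. No measurement bears on the reason for the size of this step.

From the compounds shown here alone, it remains open whether a longer chain, an amine or a carboxylic acid on this position would move the number beyond the scatter.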